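A few compounds are considered here, and "the series" means these few. Any claim that something is new, unique, unknown or untested is made for them only; others in the source may bear on it.

Compound 3 `CCc1cccc(CC)c1-n1nncc1CN1C(=O)C2(C(C#N)=C(N)Oc3c(N)cc4nc5ccccc5nc4c32)c2ccccc21` belongs to a set of three compounds that share one core and differ only in the phenyl group placed on an aromatic nitrogen of a five-membered aromatic ring with 3 nitrogen. In a functional assay on MCF7 cells (Homo sapiens) for antiproliferative activity, read by MTT assay, with a stated time of 48 h (on this read-out higher numbers stand for weaker inhibition and lower numbers for stronger inhibition), compound 3 gives only a limit of the assay, > 50000 nM. Compound 2 `N#CC1=C(N)Oc2c(N)cc3nc4ccccc4nc3c2C12C(=O)N(Cc1cnnn1-c1ccc([N+](=O)[O-])cc1)c1ccccc12` likewise gives a limit in this assay, > 50000 nM. Going by the values given here, compound 1 `N#CC1=C(N)Oc2c(N)cc3nc4ccccc4nc3c2C12C(=O)N(Cc1cnnn1-c1ccccc1Br)c1ccccc12`, carrying 2-bromophenyl, is the only one to give a number in this assay, 30700 nM. The steps of an at least 1.6-fold higher number from compound 1 to compound 2 (0.21 log units; that floor lies within the scatter) and an at least 1.6-fold higher number from compound 1 to compound 3 (0.21 log units; that floor lies within the scatter) therefore have floors that lie within the scatter, and the step that the two limits leave unreadable from compound 2 to compound 3 cannot be sized at all; as the limit of > 50000 nM in this assay, at which 2 of the 3 values shown sit, shows, most of the set rests at the limit.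

Compound 4 `COc1ccc(OC)c(-n2nncc2CN2C(=O)C3(C(C#N)=C(N)Oc4c(N)cc5nc6ccccc6nc5c43)c3ccccc32)c1` differs from compound 3 in one place: 2,5-dimethoxyphenyl in place of 2,6-diethylphenyl on an aromatic nitrogen. Among the compounds with values here, none of the measured steps shows a change beyond the scatter, and two of them cannot be read, so no direction of change in this assay can be expected for compound 4 beyond the scatter. Compound 4 is thus estimated to give 45000 nM in this assay, with a range from 15000 nM to 120000 nM. The step of an at least 1.1-fold lower number from compound 3 to compound 4 (0.04 log units; that floor lies within the scatter) that this estimate means is expected to be small.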

Compound 4, half-maximal inhibitory concentration: 28100 nM
Compound 4: the middle estimate sits 1.6-fold (0.20 log units) above what was measured; the measured number falls inside the stated range.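

Compound 4 is the second compound of the set to give a number rather than a limit in this assay, so a readable value at this place does not depend on 2-bromophenyl. Putting 2,5-dimethoxyphenyl on the aromatic nitrogen gives an at least 1.7-fold lower number from compound 3 to compound 4 (0.25 log units; that floor lies within the scatter) and an at least 1.7-fold lower number from compound 2 to compound 4 (0.25 log units; that floor lies within the scatter), so both steps point the same way, but neither floor shows a change beyond the scatter. Against 2-bromophenyl, the same group gives a 1.1-fold lower number from compound 1 to compound 4 (0.04 log units; within the scatter), so compound 1 and compound 4 cannot be told apart in this assay, even though 2,5-dimethoxyphenyl and 2-bromophenyl are quite different groups.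

On these data alone, how far compound 2 and compound 3 lie past their limits stays unknown, and the step between them cannot be read: the limit of > 50000 nM in this assay, at which 2 of the 4 values shown sit. As far as these compounds go, whether a phenyl ring bearing an amine or a carboxylic acid, or a longer alkyl chain in place of the phenyl ring, would move the value beyond the scatter remains open.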